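The compounds below may be only part of what the source reports. "The series", "measured", "known", "first", "only" and "open" are said of these compounds alone.

In a functional assay on GC3/C1 cells (Homo sapiens) for cytotoxicity, read by MTT assay, with a stated time of 6 days (on this read-out lower numbers stand for stronger inhibition and higher numbers for weaker inhibition), compound 2 (`CC(=O)N[C@@H](CSC(=O)Nc1ccc(F)cc1)C(=O)O`) gives 114000 nM and compound 1 (`CC(=O)N[C@@H](CSC(=O)Nc1ccc(Br)cc1)C(=O)O`) gives 63500 nM, so the two sit within the usual scatter of each other. Compound 3 (`CC(=O)N[C@@H](CSC(=O)Nc1ccc(Cl)cc1)C(=O)O`) is still unmeasured. It differs from compound 2 by chloro in place of fluoro on an aromatic carbon, para to a large group (chloro in place of fluoro on an aromatic carbon). Among the compounds with values here, the one measured step that bears on this is fluoro in place of bromo on an aromatic carbon (a 1.8-fold higher number from compound 1 to compound 2 (0.25 log units; within the scatter)), and it stays within the scatter. No step beyond the scatter is therefore expected in this assay, and the estimated move is small (a 1.3-fold lower number from compound 2 to compound 3 (0.13 log units; within the scatter)). Compound 3 is estimated at 85000 nM (from 50000 nM to 145000 nM).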

Compound 3, half-maximal inhibitory concentration in the GC3/C1 assay: 8130 nM
Compound 3: the middle estimate sits 10-fold (1.02 log units) above what was measured, outside the stated range (below it).
By their numbers in the GC3/C1 assay, from the lowest: compound 3; then compounds 1 and 2 (each within the scatter of the next).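

In the GC3/C1 assay, the halogen para to a large group proves to make a real difference: compound 3, with chloro, gives 8130 nM, which is a 14-fold lower number from compound 2 to compound 3 (1.15 log units; beyond the scatter) and a 7.8-fold lower number from compound 1 to compound 3 (0.89 log units; beyond the scatter), while fluoro and bromo had stayed within the scatter of each other (a 1.8-fold higher number from compound 1 to compound 2 (0.25 log units; within the scatter)), so chloro stands apart from both. In a physicochemical assay for solubility, in phosphate buffer, at pH 7.4 (a higher number here means a more soluble compound, a lower number a less soluble compound), compound 2 gives 26 ug/mL and compound 3 gives 26 ug/mL, so the same exchange gives no change at the digits printed from compound 2 to compound 3 (within the scatter), and the gain in the cell read-out comes with no shift in solubility. Nothing at hand explains why chloro stands apart. Still open, going by these compounds, is whether this low number is special to chloro, or whether a methyl or trifluoromethyl group at the same place would give a similar one.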